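Methoxy in place of nitro on compound 1

The source may report more compounds than this note shows. Statements on the series, on what has been measured and on what is new or still open speak of the compounds shown alone.

Of the compounds shown here, three have numbers so far in a functional assay on Huh-7 cells (Homo sapiens) for inhibition, read by sulforhodamine B assay, with a stated time of 72 h; a higher number here means a weaker inhibitor, a lower number a stronger inhibitor. Compound 1 (`COc1ccc2cc(C(C)c3nnc4n3N=C(c3ccc([N+](=O)[O-])cc3)CS4)ccc2c1`) gives 14700 nM. Compound 2 (`CC(c1ccc(-c2ccccc2)c(F)c1)c1nnc2n1N=C(c1ccc(C(F)(F)F)cc1)CS2`) gives 9400 nM, within the scatter of compound 1. Compound 3 (`CC(c1ccc(-c2ccccc2)c(F)c1)c1n[nH]c(=S)n1N`) gives 43100 nM, a higher number than compound 1 and beyond the scatter, so compound 1 stands with compound 2 on the stronger side of these three values.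

Compound 4 (`COc1ccc(C2=Nn3c(nnc3C(C)c3ccc4cc(OC)ccc4c3)SC2)cc1`) keeps the core of compound 1 and changes one place: methoxy in place of nitro on an aromatic carbon, para to a large group, turning 4-nitrophenyl into 4-methoxyphenyl (methoxy in place of nitro on an aromatic carbon). Among the measured compounds shown here, no measured pair isolates this change, so the data give no direct size for it. No step beyond the scatter is expected in this assay, and no direction is favoured, because compound 2 at 9400 nM differs from compound 1 in more than one place and still stays within the scatter of it. The estimated step of a 1.1-fold lower number from compound 1 to compound 4 (0.05 log units; within the scatter) is therefore small. Compound 4 is expected at 13000 nM, with an estimated range of 5500 nM to 32000 nM.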

Compound 4, half-maximal inhibitory concentration: 8500 nM
Compound 4: the middle estimate sits 1.5-fold (0.18 log units) above what was measured; low and high end bracket the measured number.
By their numbers in this assay, from the lowest: compounds 4, 2 and 1 (each within the scatter of the next); then compound 3.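

Among the compounds shown here, putting 4-methoxyphenyl in place of 4-nitrophenyl gives the first single-place step, and in this assay that step is a 1.7-fold lower number from compound 1 to compound 4 (0.24 log units; within the scatter). For the compounds shown here, the place on the aromatic ring, para to a large group, therefore accepts two quite different substituents with no change that can be told from the scatter, which the earlier compounds, differing in several places at once, could not show. No measurement on these compounds speaks to why the step is this small.

Open, as far as these compounds go, is whether an amine, a carboxylic acid or a longer alkoxy chain at this place would also stay within the scatter. Also open, from the compounds shown here alone, is whether the same swap would give a similar step on compound 2, which carries trifluoromethyl here.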